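From Fluoro to Methoxy at One Aromatic Carbon

The source may report more compounds than this note shows. Statements on the series, on what has been measured and on what is new or still open speak of the compounds shown alone.

Of the compounds shown here, two sharing one core have been measured in a functional assay on the whole organism (strain Kunming) with Mus musculus as the target, with a stated time of 0.5 h; on this read-out lower numbers stand for an effect already at smaller amounts and higher numbers for an effect only at larger amounts of compound. Compound 1 (`COc1cc(OC)c(OC)cc1/C=C/COC(=O)/C=C/c1ccc(Br)cc1`) gives 193 mg/kg, and compound 2 (`COc1cc(OC)c(OC)cc1/C=C/COC(=O)/C=C/c1ccc(F)cc1`) gives 167 mg/kg. Compound 2 thus stands level with compound 1, as the two values lie within the scatter of each other.

Compound 3 (`COc1ccc(/C=C/C(=O)OC/C=C/c2cc(OC)c(OC)cc2OC)cc1`) has not yet been measured. It carries methoxy in place of fluoro on an aromatic carbon, para to a large group: methoxy in place of fluoro on an aromatic carbon. For the measured compounds named here, no measured compound shows what methoxy does at this carbon, so the evidence is thin. Going by the values given here, the only guide is the exchange of bromo for fluoro at the same carbon, a 1.2-fold lower number from compound 1 to compound 2 (0.06 log units; within the scatter). On that single step, no change beyond the scatter is expected in this assay, and a larger move cannot be excluded. The estimated step is a 1.0-fold higher number from compound 2 to compound 3 (0.02 log units; within the scatter), which is expected to stay within the scatter. For compound 3 the estimated value is 175 mg/kg, with an expected range from 95 mg/kg to 320 mg/kg.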

Compound 3, dose for half-maximal effect: 244 mg/kg
The estimate for compound 3 lay 1.4-fold (0.14 log units) below the measured number; low and high end bracket the measured number.
By their numbers in this assay, from the lowest: compounds 2, 1 and 3 (each within the scatter of the next).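

In this assay, for the compounds shown here, methoxy is the first group at this aromatic carbon, para to a large group, that is not a halogen, yet the exchange stays within the scatter against both earlier groups: the fluoro compound gives way to the methoxy compound with a 1.5-fold higher number from compound 2 to compound 3 (0.16 log units; within the scatter) and the bromo compound with a 1.3-fold higher number from compound 1 to compound 3 (0.10 log units; within the scatter). Going by these compounds alone, all three pairs of compounds now lie within the scatter of each other, so bromo, fluoro and methoxy at this carbon cannot be told apart on this read-out, and the 4-fluorophenyl to 4-methoxyphenyl exchange is the widest structural change at this place so far without a clear separation in the numbers. No supporting measurement is available that would account for this result.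

On these data alone, whether an amine, a carboxylic acid or a longer chain at the same carbon would carry the number beyond the scatter remains open. Equally open, as far as these compounds go, is whether this carbon would behave the same way if the three methoxy groups on the other aromatic ring of the shared core were exchanged for hydroxy groups.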